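This account rests on a few compounds, and the source may have more. Where it says the series, first, only, none or still open, it means among the compounds named here.

Of the compounds shown here, three built on a shared core have been measured in a physicochemical assay for solubility, read by LC-MS, in phosphate buffer, with a stated time of 24 h, at pH 6.8 (on this read-out higher numbers stand for higher solubility and lower numbers for lower solubility), so far. There, compound 1 `C[C@@H](c1ccc(NC(=O)N2CC(c3cccnc3)C2)cc1)N1Cc2ccccc2C1=O` gives 130000 nM and compound 2 `C[C@H](NC(=O)c1cccc(F)c1)c1ccc(NC(=O)N2CC(c3cccnc3)C2)cc1` gives 11000 nM as its reading. Compound 3 `C[C@H](NC(=O)[C@@H]1CCCN1C)c1ccc(NC(=O)N2CC(c3cccnc3)C2)cc1` gives > 1000000 nM as its entry, which is a limit of the assay and not a number.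

The next compound changes one group of compound 3. Going to compound 4 `CCC(=O)N[C@@H](C)c1ccc(NC(=O)N2CC(c3cccnc3)C2)cc1`, the difference is ethyl in place of 1-methylpyrrolidin-2-yl on a carbonyl carbon and amounts to ethyl in place of 1-methylpyrrolidin-2-yl on a carbonyl carbon. The nearest measured change sits on the same kind of carbon: 1-methylpyrrolidin-2-yl in place of 3-fluorophenyl gave an at least 90-fold higher number from compound 2 to compound 3 (1.95 log units; beyond the scatter) and counts as large. The step of an at least 7.6-fold higher number from compound 1 to compound 3 (0.88 log units; beyond the scatter) points the same way, while a 12-fold lower number from compound 1 to compound 2 (1.07 log units; beyond the scatter) shows that the other two compounds also sit far apart.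

Compound 3 alone carries 1-methylpyrrolidin-2-yl, and it alone stands at the limit. On the strength of an at least 90-fold higher number from compound 2 to compound 3 (1.95 log units; beyond the scatter) as the closest guide, a large step to a lower number is expected in this assay when that group goes. The expected step is an at least 12-fold lower number from compound 3 to compound 4 (1.09 log units; beyond the scatter) as an estimate. For compound 4 the estimated value is 80000 nM with 15000 nM and 400000 nM as the ends of the expected range.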

Compound 4, solubility: 700000 nM
Estimate against measurement, compound 4: 8.8-fold (0.94 log units) below; the measured number lies above the stated range.
By their numbers in this assay, from the lowest: compound 2; then compound 1; then compound 4. At a limit, above all of these: compound 3.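

Compound 4 shows that a number far above that of compound 2 does not need 1-methylpyrrolidin-2-yl on the carbonyl carbon: with the ringless ethyl there, this assay gives a 64-fold higher number from compound 2 to compound 4 (1.80 log units; beyond the scatter) and, with propanoylamino in place of the larger ring-bearing group of compound 1 on the saturated chain carbon, a 5.4-fold higher number from compound 1 to compound 4 (0.73 log units; beyond the scatter) as well. Compound 3 holds a limit of the assay and not a number: the limit of > 1000000 nM in this assay, at which 1 of the 4 values shown sits. On these data alone, the step against it, an at least 1.4-fold lower number from compound 3 to compound 4 (0.15 log units; that floor lies within the scatter) as it stands, is only a floor, so the true size of this change stays unknown.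

Among the compounds shown, only ethyl, 1-methylpyrrolidin-2-yl and 3-fluorophenyl sit on this carbonyl carbon, so they do not tell whether a longer chain such as butyl, or an open-chain amine, would read nearer compound 4 or compound 2. Nor do they tell whether the low number of compound 2 goes with the aromatic ring or with its fluorine, a question that a plain phenyl group would help to separate.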